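From methyl to isopropyl: what size of step?

The source may report more compounds than this note shows. Statements on the series, on what has been measured and on what is new or still open speak of the compounds shown alone.

Compound 1 (`COc1cccc(Nc2nc(C)cc(N(C)C)n2)c1`): > 50100 nM (a limit)
Compound 2 (`COc1cc(Nc2nc(C)cc(N(C)C)n2)ccc1F`): 31600 nM
Compound 3 (`COc1cc(Nc2nc(C(C)C)cc(N(C)C)n2)ccc1F`): not yet measured

For the measured compounds named here, in an ADME assay on Vero cells (Chlorocebus sabaeus) for cytotoxicity (a lower number here means that less compound is needed, a higher number that more compound is needed for the effect), compound 2 gives 31600 nM and holds the only exact number so far. Compound 1 reads > 50100 nM and this is a limit of the assay, not a number.

Compound 3 carries isopropyl in place of methyl on an aromatic carbon and is otherwise the same as compound 2. The change lies next to the ring nitrogen.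

Going by the values given here, only one measured step exists, an at least 1.5-fold lower number from compound 1 to compound 2 (0.20 log units; that floor lies within the scatter) and it comes from fluoro in place of hydrogen at a different place. It therefore gives no direct measure of what a change at the methyl will do, and its floor does not show a step beyond the scatter. With so little to go on, the expectation stays close to compound 2 at 31600 nM in this assay with only a slight lean toward a lower number. The expected change is a 1.3-fold lower number from compound 2 to compound 3 (0.10 log units; within the scatter) and no step beyond the scatter is expected. For compound 3 the estimate is 25000 nM (11000 nM to 50000 nM).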

Compound 3, half-maximal effective concentration: > 50100 nM
Compound 3: only a limit was reported; the forecaster's own chance of this, stated with the estimate: 25%; at least 2.0-fold (0.30 log units) between middle value and limit.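

In this assay compound 3 gives > 50100 nM, which is a limit of the assay and not a number. For the compounds shown here, this is the first look at a change at the position next to the ring nitrogen: isopropyl in place of methyl gives an at least 1.5-fold higher number from compound 2 to compound 3 (0.20 log units; that floor lies within the scatter), so the larger group brings no fall in the number, although the step as printed does not establish a rise beyond the scatter. The true size of this step stays unknown, and any real difference may be hidden, because the reading of compound 3 stops at the end of the measurable range: the limit of > 50100 nM in this assay, at which 2 of the 3 values shown sit.

The compounds shown leave open how the number changes across the sizes between and beyond these two groups, for example with ethyl or tert-butyl at this position. They also leave open whether a group of a different kind here, such as an amine or a carboxylic acid, would give a number that can be read as an exact value rather than as a limit.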